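Swapping the halogenated ring on a shared core

The source may hold more compounds than are shown below. What is called first, only, known or untested is meant among the compounds shown, and "the series" means these compounds.

Three analogues built on one core have been tested in a functional assay on A549 cells (Homo sapiens) for cytotoxicity, read by MTT assay, with a stated time of 72 h; a higher number here means a weaker inhibitor, a lower number a stronger inhibitor. Compound 1 `COc1cccc(/C=C2\CCC/C(=C\c3ccccc3Br)C2=O)c1OC` gives only a limit of the assay, > 20000 nM. Compound 2 `COc1cccc(/C=C2\CCC/C(=C\c3cc(Cl)cc(Cl)c3)C2=O)c1OC` gives 12500 nM. Compound 3 `COc1ccc(/C=C2\CCC/C(=C\c3ccc(Br)cc3)C2=O)cc1OC` gives 16000 nM, a value that sits alongside that of compound 2 within the scatter. Compound 4 `COc1ccc(/C=C2\CCC/C(=C\c3cc(Cl)cc(Cl)c3)C2=O)cc1OC` is not yet measured and differs from compound 3 in one place: 3,5-dichlorophenyl in place of 4-bromophenyl on a double-bonded chain carbon bound to a double-bonded ring carbon. Among the compounds with values here, the only measured step that bears on it is the related exchange an at least 1.6-fold lower number from compound 1 to compound 2 (0.20 log units; that floor lies within the scatter), too small to separate from the scatter, and it starts from a limit (the limit of > 20000 nM in this assay, at which 1 of the 3 values shown sits). The step of a 1.3-fold lower number from compound 3 to compound 4 (0.11 log units; within the scatter) in this assay is therefore expected to stay within the scatter. The estimate for compound 4 is 12500 nM, between 6000 nM and 26000 nM.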

Compound 4, half-maximal inhibitory concentration: 5500 nM
Compound 4: the middle estimate sits 2.3-fold (0.36 log units) above what was measured; the measured number lies below the stated range.
By their numbers in this assay, from the lowest: compound 4; then compounds 2 and 3 (each within the scatter of the next). At a limit, above all of these: compound 1.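

In this assay, putting 3,5-dichlorophenyl in place of 4-bromophenyl gives a 2.9-fold lower number from compound 3 to compound 4 (0.46 log units; beyond the scatter), the first step among these compounds that clears the scatter. So the ring carried at this place can change the measured number on this shared core, though only modestly. The earlier exchange, in which 2-bromophenyl left, could not show this because it starts from a limit: the limit of > 20000 nM in this assay, at which 1 of the 4 values shown sits.

Still open, on these data alone, is whether the number of chlorine atoms or where they sit matters more. The compounds shown also leave open how a phenyl ring carrying an amine or a carboxylic acid would behave here.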